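The source may hold more compounds than are shown below. What is called first, only, known or untested is meant among the compounds shown, and "the series" means these compounds.

Three measured compounds, all tested in a functional assay on HL-60 cells (Homo sapiens) for cytotoxicity, read by WST assay, with a stated time of 48 h; on this read-out lower numbers stand for stronger inhibition and higher numbers for weaker inhibition:

Compound 1, `O=[N+]([O-])c1ccc(/C=C/C[C@H]2C[C@@H]([C@@H](O)c3ccccc3)CO[C@@H]2c2ccccc2)cc1`, gives 4880 nM.
Compound 2, `O[C@@H](c1ccccc1)[C@H]1CO[C@H](c2ccccc2)[C@@H](C/C=C/c2ccc(F)cc2)C1`, gives 8110 nM.
Compound 3, `O[C@@H](c1ccccc1)[C@H]1CO[C@H](c2ccccc2)[C@@H](C/C=C/c2ccccc2F)C1`, gives 9530 nM.

All three share one core and differ only in the aromatic ring at the end of the side chain. Compound 2 and compound 3 have the same atoms joined differently: 2-fluorophenyl in place of 4-fluorophenyl on a double-bonded chain carbon bound to a double-bonded chain carbon. In this assay this gives a 1.2-fold higher number from compound 2 to compound 3 (0.07 log units; within the scatter), so the two rings are not told apart here. Going from compound 2 to compound 1 the change is nitro in place of fluoro on an aromatic carbon, and it gives a 1.7-fold lower number from compound 2 to compound 1 (0.22 log units; within the scatter), a small step that stays within the scatter. Compound 1 and compound 3 are joined by a 2.0-fold higher number from compound 1 to compound 3 (0.29 log units; within the scatter).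

Compound 4, `O=[N+]([O-])c1ccccc1/C=C/C[C@H]1C[C@@H]([C@@H](O)c2ccccc2)CO[C@@H]1c1ccccc1`, is not yet measured. It comes from compound 3 by nitro in place of fluoro on an aromatic carbon. For the measured compounds named here, this is the same kind of change as the one from compound 2 to compound 1, but not the same: there the nitro sits para to a large group, here it sits ortho to a large group. Going by the values given here, the expectation for compound 4 rests on the one measured example, the step from compound 2 to compound 1 in this assay, which was small. The expected step is therefore also small, a 1.5-fold lower number from compound 3 to compound 4 (0.17 log units; within the scatter), with wide uncertainty because the place on the ring is different. Compound 4 is estimated to give 6500 nM in this assay, most likely between 3000 nM and 14000 nM.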

Compound 4, half-maximal inhibitory concentration: 7250 nM
Estimate against measurement, compound 4: 1.1-fold (0.05 log units) below, and the stated range covers the measured number.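

In this assay, nitro in place of fluoro on the aromatic ring gives a 1.3-fold lower number from compound 3 to compound 4 (0.12 log units; within the scatter), while the two pairs that differ in the whole ring give a 1.1-fold lower number from compound 2 to compound 4 (0.05 log units; within the scatter) and a 1.5-fold higher number from compound 1 to compound 4 (0.17 log units; within the scatter). Set beside the earlier case, the same change behaves alike on the two cores, with no difference that can be told from the scatter: the same change on two cores in this assay, a 1.7-fold lower number (0.22 log units; within the scatter) from compound 2 to compound 1 and a 1.3-fold lower number (0.12 log units; within the scatter) from compound 3 to compound 4, 1.3-fold (0.10 log units) apart, within the scatter of two such steps This shows only that swapping fluoro for nitro leaves the number within the scatter in both pairs, so there is no sign that the result depends on which of the two cores carries the change, but it does not show a real gain from nitro, and two pairs cannot establish a rule for other cores or other places on the ring.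

The compounds shown leave open whether any change at the end of the side chain can move the number beyond the scatter, since the rings here carry only fluoro or nitro. From the compounds shown here alone, what an amine or a carboxylic acid on that ring would do remains unknown, as does the effect of a longer chain between the ring and the shared core.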